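Hydrazone aryl swap: from compound 3 to compound 4

A few compounds are considered here, and "the series" means these few. Any claim that something is new, unique, unknown or untested is made for them only; others in the source may bear on it.

The series shares one core and varies the aryl group on the carbon with a double bond to nitrogen. In a functional assay on MCF7 cells (Homo sapiens) for antiproliferative activity, read by MTT assay, with a stated time of 72 h (on this read-out higher numbers stand for weaker inhibition and lower numbers for stronger inhibition), compound 1 `CCCSc1nc(N/N=C/c2cccs2)c2nnn(Cc3ccccc3)c2n1` gives only a limit, > 64000 nM (the limit of > 64000 nM in this assay, at which 1 of the 3 values shown sits). Compound 2 `CCCSc1nc(N/N=C/c2ccc(N(C)C)cc2)c2nnn(Cc3ccccc3)c2n1` gives 12200 nM in this assay, and compound 3 `CCCSc1nc(N/N=C/c2c(O)ccc3ccccc23)c2nnn(Cc3ccccc3)c2n1` gives 6400 nM. The steps are an at least 5.2-fold lower number from compound 1 to compound 2 (0.71 log units; beyond the scatter) and an at least 10-fold lower number from compound 1 to compound 3 (1.00 log units; beyond the scatter), while a 1.9-fold lower number from compound 2 to compound 3 (0.28 log units; within the scatter). Compound 3 thus holds the lowest of the two numbers, with compound 2 nearest and within the scatter of it.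

Compound 4 `CCCSc1nc(N/N=C/c2ccc3ccccc3c2)c2nnn(Cc3ccccc3)c2n1` differs from compound 3 by naphthalen-2-yl in place of 2-hydroxynaphthalen-1-yl on a carbon with a double bond to nitrogen. Going by the values given here, the only measured step that exchanges one aryl for another between two real numbers is the one from compound 2 to compound 3, and it stayed within the scatter; the steps from compound 1 are bounded by a limit and give no size. Among the compounds with values here, no measured step removes the hydroxy group or moves the attachment point, so nothing shows the effect of this change in this assay. A step no larger than the scatter is expected, with wide uncertainty in both directions. Compound 4 is therefore estimated at 9000 nM, between 3000 nM and 30000 nM. This corresponds to an expected 1.4-fold higher number from compound 3 to compound 4 (0.15 log units; within the scatter).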

Compound 4, half-maximal inhibitory concentration: > 64000 nM
Compound 4: a limit, no number; the forecaster's own chance of this, stated with the estimate: 10%; middle value at least 7.1-fold (0.85 log units) away from the limit.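

Naphthalen-2-yl in place of 2-hydroxynaphthalen-1-yl on a carbon with a double bond to nitrogen gives an at least 10-fold higher number from compound 3 to compound 4 (1.00 log units; beyond the scatter), the first step at this position that leaves one two-ring aryl for another, and it lies beyond the scatter. Both groups have 2 six-membered aromatic rings of carbon only, so that ring count alone does not keep a compound in the measurable range here, and the single-ring 4-(dimethylamino)phenyl group also compares favourably, with an at least 5.2-fold higher number from compound 2 to compound 4 (0.71 log units; beyond the scatter). Compound 4 gives only a limit in this assay, so both steps are minimum sizes, and the step from compound 1, which also sits at the limit, cannot be read: the limit of > 64000 nM in this assay, at which 2 of the 4 values shown sit.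

The step from compound 3 to compound 4 loses the hydroxy group and changes the attachment point together, and the compounds shown do not separate the two changes. Going by these compounds, whether naphthalen-1-yl or 2-methoxynaphthalen-1-yl on this carbon would read like compound 3 or like compound 4 stays open.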